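Swapping an aryl group for an aryl ether on the piperidine

This account rests on a few compounds, and the source may have more. Where it says the series, first, only, none or still open, it means among the compounds named here.

Measured compounds and their values:
- Compound 1, `FC(F)(F)c1c(CN2CCCC(c3ccccc3)C2)ccn2c(CC3CC3)nnc12`: 240%
- Compound 2, `CC1(c2ccccc2)CCCN(Cc2ccn3c(CC4CC4)nnc3c2C(F)(F)F)C1`: 278%
- Compound 3, `FC(F)(F)c1c(CN2CCC(c3ccccc3Cl)CC2)ccn2c(CC3CC3)nnc12`: 328%

These three share one core and were tested in an assay on CHO cells for positive allosteric modulation of metabotropic glutamate receptor 2 (Homo sapiens), read by scintillation counting, with a stated time of 30 min; a higher number here means a larger maximal response, a lower number a smaller maximal response. Compound 3 stands highest of the three, beyond the scatter above both compound 2 and compound 1. Among the compounds with values here, the one step measured between close pairs, a number 38 percentage points higher from compound 1 to compound 2 (beyond the scatter), changes a different part of the molecule than the step now followed.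

Compound 4, `Fc1ccc(OC2CCN(Cc3ccn4c(CC5CC5)nnc4c3C(F)(F)F)CC2)c(F)c1`, differs from compound 3 in one place: 2,4-difluorophenoxy in place of 2-chlorophenyl on a saturated ring carbon. Within the data shown here, no measured step covers this kind of exchange, so the expectation rests only on the level of compound 3. A moderate change in either direction cannot be excluded; the step from compound 3 to compound 4 is expected to be a number 38 percentage points lower from compound 3 to compound 4 (beyond the scatter). Compound 4 is therefore expected to give about 290%, within a range of 210% to 370%.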

Compound 4, largest response reached (Emax), in percent of the reference or control that the assay uses: 272%
Estimate against measurement, compound 4: 18 percentage points above; the measured number falls inside the stated range.
By their numbers in this assay, from the lowest: compound 1; then compounds 4 and 2 (each within the scatter of the next); then compound 3.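

In this assay the group on this saturated ring carbon matters: 2,4-difluorophenoxy in place of 2-chlorophenyl gives a number 56 percentage points lower from compound 3 to compound 4 (beyond the scatter) and so lowers the maximal response. Even so, compound 4 reaches 272% with a phenoxy group here, so this position can carry an oxygen-linked aromatic ring and still give a clear response. No measurement shown here explains the drop.

The exchange alters both the oxygen link and the halogens, and these compounds cannot separate the two. On these data alone, how an amine or a carboxylic acid on this ring carbon would behave also remains open.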